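This account rests on a few compounds, and the source may have more. Where it says the series, first, only, none or still open, it means among the compounds named here.

Measured so far in a functional assay on HeLa cells (Homo sapiens) for inhibition, read by MTT assay, with a stated time of 72 h; on this read-out lower numbers stand for stronger inhibition and higher numbers for weaker inhibition: compound 1 `O=C(O)/C=C/C(=O)c1ccc(Cl)c(Cl)c1` gives 28300 nM; compound 2 `Cc1cc(C2CCCCC2)c(C)cc1C(=O)/C=C/C(=O)O` gives 2380 nM.

Compound 1 holds the higher of the two numbers, so it is the weaker inhibitor of the pair, and its gap to compound 2 lies beyond the usual scatter. Compound 3 `O=C(O)/C=C/C(=O)c1ccc(Cl)cc1` differs from compound 1 by hydrogen in place of chloro on an aromatic carbon. Going by the values given here, no pair of measured compounds shows what this change does here, so the expectation rests on compound 1 alone. For compound 3 a small step toward a higher number is expected, a 1.8-fold higher number from compound 1 to compound 3 (0.25 log units; within the scatter), roughly at the edge of the scatter. Compound 3 is therefore estimated at 50000 nM, within 20000 nM to 150000 nM.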

Compound 3, half-maximal inhibitory concentration: 25400 nM
Beside the measured number, compound 3's estimate is 2.0-fold (0.29 log units) above it; the measured number falls inside the stated range.
By their numbers in this assay, from the lowest: compound 2; then compounds 3 and 1 (each within the scatter of the next).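

Putting hydrogen in place of the chloro group on this aromatic carbon, ortho to the other chloro group, gives a 1.1-fold lower number from compound 1 to compound 3 (0.05 log units; within the scatter) in this assay. This chloro group can therefore be lost without a measurable change in this assay, and the two compounds cannot be told apart on these numbers. Nothing available explains this result. Still open, going by these compounds, is whether an amine or a methoxy group on this carbon would shift the number. The contribution of the remaining chloro group is also open, since no compound shown replaces it alone.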